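Pyridyl acrylamide swap on a quinazoline-free shared core

A few compounds are considered here, and "the series" means these few. Any claim that something is new, unique, unknown or untested is made for them only; others in the source may bear on it.

Of the compounds shown here, two sharing one core have been measured in a functional assay on HepG2 cells (Homo sapiens) for antiproliferative activity, read by MTT assay, with a stated time of 48 h; on this read-out higher numbers stand for weaker inhibition and lower numbers for stronger inhibition. Compound 1, `CCCCNc1ccc2ncnc(Nc3cccc(Cl)c3)c2c1`, gives 7850 nM in this assay. Compound 2, `O=C(/C=C/c1cccnc1)Nc1ccc2ncnc(Nc3cccc(Cl)c3)c2c1`, gives 9120 nM in this assay, the higher of the two numbers shown, yet its nearest neighbour is compound 1 and the two values sit within the scatter of one another, so no order between them can be claimed.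

Compound 3, `Cc1cccc(/C=C/C(=O)Nc2ccc3ncnc(Nc4cccc(Cl)c4)c3c2)n1`, has not yet been measured. It differs from compound 2 in one place: 6-methylpyridin-2-yl in place of pyridin-3-yl on a double-bonded chain carbon bound to a double-bonded chain carbon. For the measured compounds named here, nothing among the measured compounds tracks such a swap of one pyridyl ring for another on the chain, so no step between measured compounds can be drawn on. With compound 1 and compound 2 both near the same level, the expectation is for no change beyond the scatter in this assay, in either direction. The expected step from compound 2 to compound 3 is a 1.1-fold lower number from compound 2 to compound 3 (0.03 log units; within the scatter). Compound 3 is estimated to give 8500 nM in this assay, with a range from 3000 nM to 25000 nM.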

Compound 3, half-maximal inhibitory concentration: 4820 nM
For compound 3 the middle estimate is 1.8-fold (0.25 log units) above the measured one, within the range that was stated.
By their numbers in this assay, from the lowest: compounds 3, 1 and 2 (each within the scatter of the next).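

In this assay, the change to 6-methylpyridin-2-yl in place of pyridin-3-yl on a double-bonded chain carbon bound to a double-bonded chain carbon gives a 1.9-fold lower number from compound 2 to compound 3 (0.28 log units; within the scatter), the only step at this position among the compounds shown. This position therefore accepts this swap of one pyridyl group for another, with its added methyl and different point of attachment, without a step beyond the scatter, though a single pair cannot show whether that holds for other groups there. Nothing available explains the size of this step or connects it to any feature of the two groups.

The compounds shown leave open how the two parts of the swap would read apart, since plain pyridin-2-yl and 6-methylpyridin-3-yl would be needed to separate the methyl from the point of attachment. They also leave open whether a more different group at this place, such as phenyl, or a pyridyl ring carrying a carboxylic acid or a dimethylamino group, would give a step beyond the scatter in this assay.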